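From Phenyl to Dimethylamino: A Half-Life Estimate

The source may report more compounds than this note shows. Statements on the series, on what has been measured and on what is new or still open speak of the compounds shown alone.

In an ADME assay for pharmacokinetics, read by LC-MS, in phosphate buffer, with a stated time of 120 min, at pH 7.4, tested at 1 uM, in the presence of a further agent that is not named here (on this read-out higher numbers stand for a longer-lived compound and lower numbers for a shorter-lived compound), compound 1 `C=C(Cc1ccccc1)C(=O)Nc1ccccc1` gives > 8.53 h, which is a limit of the assay and not a number. Compound 1 thus stands at the limit of > 8.53 h in this assay, at which 1 of the 2 values shown sits. Compound 2 `CCN(CC)C/C=C/C(=O)Nc1ccccc1`, whose chain carries an amino group, gives a true number of 2.83 h. For the measured compounds named here, no two measured compounds differ in only one place, so any step size here is a judgement.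

Compound 3 `C=C(CN(C)C)C(=O)Nc1ccccc1` has dimethylamino in place of phenyl on a saturated chain carbon bound to a double-bonded chain carbon. It too carries an amino group, as does compound 2 at 2.83 h, so a shorter half-life is expected in this assay. The expected change, beyond the usual scatter, is an at least 3.4-fold lower number from compound 1 to compound 3 (0.53 log units; beyond the scatter). For compound 3 the estimated half-life is 2.5 h, with an expected range of 0.5 h to 9 h.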

Compound 3, half-life: < 0.0334 h
Compound 3 gave a limit, no number (the forecaster's own chance of this, stated with the estimate: 15%); middle value at least 74-fold (1.87 log units) away from the limit.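

In this assay, for the compounds shown here, the first single change that can be read, dimethylamino in place of phenyl on a saturated chain carbon bound to a double-bonded chain carbon, gives an at least 250-fold lower number from compound 1 to compound 3 (2.40 log units; beyond the scatter) at this position, so the half-life depends strongly on what sits at this place. For compound 1 the result is a limit and not a number: the limit of > 8.53 h in this assay, at which 1 of the 3 values shown sits. For compound 3 the result is also a limit and not a number: the limit of < 0.0334 h in this assay, at which 1 of the 3 values shown sits.

The compounds shown do not tell whether the drop follows the arrival of the nitrogen or the departure of the phenyl ring. A cyclohexyl group, which has a ring and no nitrogen, and a piperidine, which has both, would set these two apart at the same place on the chain.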